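Ethynyl removal on an imidazole core: cytotoxicity notes

The source may report more compounds than this note shows. Statements on the series, on what has been measured and on what is new or still open speak of the compounds shown alone.

Measured so far:
compound 1 `C#Cc1nccn1C#Cc1ccccc1`, 5000 nM
compound 2 `C#Cc1nc(-c2ccccc2)cn1C#C`, 2500 nM
compound 3 `C(#Cn1ccnc1)c1ccccc1`, 9200 nM

In a functional assay on A549 cells (Homo sapiens) for cytotoxicity, read by resazurin assay, with a stated time of 72 h (on this read-out lower numbers stand for stronger inhibition and higher numbers for weaker inhibition), compound 1 gives 5000 nM, and compound 3 gives 9200 nM. The change from compound 1 to compound 3 is hydrogen in place of ethynyl on an aromatic carbon. It produced a 1.8-fold higher number from compound 1 to compound 3 (0.26 log units; within the scatter).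

Compound 2 is built from the same atoms as compound 1, joined differently; the difference between the two cores is not broken down here. In this assay compound 2 gives 2500 nM, which is the lowest of the three numbers, but its gap to compound 1 lies within the scatter, so no order between compound 1 and compound 2 is claimed. Its gap to compound 3 lies beyond the scatter.

Compound 4 `C#Cn1cnc(-c2ccccc2)c1` is not yet measured. From compound 2 it differs by hydrogen in place of ethynyl on an aromatic carbon. This is the same kind of change as that from compound 1 to compound 3, not the same change: in compound 2 the changed carbon is "next to the ring atom that bears an ethynyl group (2 heavy atoms); two ring bonds from the ring atom that bears a group of 6 heavy atoms", whereas in compound 1 it is "next to the ring atom that bears a group of 8 heavy atoms".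

Among the measured compounds shown here, because the only precedent, a 1.8-fold higher number from compound 1 to compound 3 (0.26 log units; within the scatter), lay within the scatter, the step from compound 2 to compound 4 is expected to be small as well, about a 1.8-fold higher number from compound 2 to compound 4 (0.26 log units; within the scatter). In this assay compound 4 is therefore estimated at 4500 nM, with a likely range from 2000 nM to 10000 nM.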

Compound 4, half-maximal inhibitory concentration: 1100 nM
For compound 4 the middle estimate is 4.1-fold (0.61 log units) above the measured one, outside the stated range (below it).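

In this assay, hydrogen in place of ethynyl on the aromatic carbon between two ring nitrogen atoms of compound 2 gives a 2.3-fold lower number from compound 2 to compound 4 (0.36 log units; beyond the scatter), a modest step. This change therefore cannot be carried from one core to the other in this series as a fixed step, since the two readings of it differ: the same change on two cores in this assay, a 1.8-fold higher number (0.26 log units; within the scatter) from compound 1 to compound 3 and a 2.3-fold lower number (0.36 log units; beyond the scatter) from compound 2 to compound 4, 4.2-fold (0.62 log units) apart, beyond the scatter of two such steps. Among the compounds shown here, only two pairs stand behind this comparison, and the first of them is a step within the scatter; they do not show which difference between the core of compound 1 and the core of compound 2 accounts for the gap, nor do they give a rule for any further core.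

Still open, on these data alone, is whether removing ethynyl from this carbon gives a step of the same size and direction on other cores built like that of compound 2, and whether the reading holds outside this cell line. Also open, as far as these compounds go, is where compounds with an amine, a carboxylic acid or a longer chain on this carbon would fall relative to compound 2 and compound 4, since only ethynyl and hydrogen are compared there.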